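Diaryl ureas on a fused bicyclic core: nitro for trifluoromethyl

This account rests on a few compounds, and the source may have more. Where it says the series, first, only, none or still open, it means among the compounds named here.

Measured so far in a functional assay on A2780 cells (Homo sapiens) for inhibition, with a stated time of 72 h; a higher number here means a weaker inhibitor, a lower number a stronger inhibitor:
- compound 1 `CCC1(CC)CC(C)(C)Oc2ccc(NC(=O)Nc3ccc(C(F)(F)F)cc3)cc21` gives 2430 nM
- compound 2 `CCC1(CC)CC(CC)(CC)c2cc(NC(=O)Nc3ccc(C(F)(F)F)cc3)ccc2O1` gives 2000 nM
- compound 3 `CCC1(CC)CC(CC)(CC)c2cc(NC(=O)Nc3ccc([N+](=O)[O-])cc3)ccc2O1` gives 2090 nM

The three measured compounds sit close together in this assay. Compound 1 holds the highest of the three numbers, yet its gaps to compound 3 and to compound 2 are both within the scatter, so no order among them can be read. Compound 1 and compound 2 carry the same urea and the same trifluoromethyl-bearing aryl ring, but the difference between the two cores is not broken down here.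

One change is seen twice in the series. From compound 2 to compound 3 it reads nitro in place of trifluoromethyl on an aromatic carbon and the step it made was a 1.0-fold higher number from compound 2 to compound 3 (0.02 log units; within the scatter), so the exchange left the number where it was. The same change, applied to compound 1, gives compound 4 `CCC1(CC)CC(C)(C)Oc2ccc(NC(=O)Nc3ccc([N+](=O)[O-])cc3)cc21`; computed from the two structures it reads (nitro in place of trifluoromethyl on an aromatic carbon). The place lines of the two changes agree word for word, so this is the same change on a different core.

Among the measured compounds shown here, with only one precedent, the expectation for compound 4 rests on that single step: compound 4 is expected to show a 1.0-fold higher number from compound 1 to compound 4 (0.01 log units; within the scatter) because compound 2 to compound 3 gave a 1.0-fold higher number from compound 2 to compound 3 (0.02 log units; within the scatter). The estimate for compound 4 in this assay is therefore 2500 nM, with a range from 1200 nM to 5200 nM that allows the core of compound 1 to respond somewhat differently from the core of compound 2.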

Compound 4, half-maximal inhibitory concentration: 2050 nM
For compound 4 the middle estimate is 1.2-fold (0.09 log units) above the measured one; the range from low to high includes it.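

In this assay, nitro in place of trifluoromethyl on the core of compound 1 gave a 1.2-fold lower number from compound 1 to compound 4 (0.07 log units; within the scatter), so on this core too the exchange produced no readable step. Set beside the earlier step, the change carries from one core to the other without a readable difference: the same change on two cores in this assay, a 1.0-fold higher number (0.02 log units; within the scatter) from compound 2 to compound 3 and a 1.2-fold lower number (0.07 log units; within the scatter) from compound 1 to compound 4, 1.2-fold (0.09 log units) apart, within the scatter of two such steps. This supports treating 4-(trifluoromethyl)phenyl to 4-nitrophenyl as a change with no readable effect on these two cores in this one cell assay, but with both steps within the scatter there is no measurable effect to transfer, and two cores cannot establish how a third would respond or explain why the number holds.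

As far as these compounds go, it remains open whether other groups at this place on the aromatic ring, such as an amine, a carboxylic acid or a chlorine atom, would move the number in this assay beyond the scatter, which would show whether this position can affect the read-out at all. Also open, from the compounds shown here alone, is whether the flat response to this exchange would persist on a core bearing a longer chain, such as propyl or butyl, or with an amide in place of the urea.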